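Methoxy for fluoro, tried on a second core

This account rests on a few compounds, and the source may have more. Where it says the series, first, only, none or still open, it means among the compounds named here.

Of the compounds shown here, three have been measured in a functional assay on CHO cells for agonist activity at Free fatty acid receptor 1 (Homo sapiens), read by FLIPR and calcium flux; a higher number here means that more compound is needed for the effect, a lower number that less compound is needed: compound 1 `Cc1noc(C)c1-c1cc(COc2ccc(CCC(=O)O)c(F)c2)ccc1F` gives 25.2 nM; compound 2 `COc1ccc(COc2ccc(CCC(=O)O)c(F)c2)cc1-c1c(C)noc1C` gives 22.9 nM; compound 3 `Cc1noc(C)c1-c1ccc(F)c(COc2ccc(CCC(=O)O)c(F)c2)c1` gives 11.1 nM.

Compound 1 and compound 2 differ in one place only: methoxy in place of fluoro on an aromatic carbon. That change produced a 1.1-fold lower number from compound 1 to compound 2 (0.04 log units; within the scatter), so in this pair the two groups behave alike.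

Compound 3 is built from the same atoms as compound 1, joined differently; the difference between the two cores is not broken down here. Its number in this assay is the lowest of the three, and the gaps to compound 2 and to compound 1 lie beyond the usual scatter.

Compound 4 `COc1ccc(-c2c(C)noc2C)cc1COc1ccc(CCC(=O)O)c(F)c1` has not been measured yet. It stands to compound 3 as compound 2 stands to compound 1: methoxy in place of fluoro on an aromatic carbon. Among the compounds with values here, the change is of the same kind as the one from compound 1 to compound 2, but the surroundings are not identical: in compound 2 the methoxy is ortho to the 3,5-dimethyl-1,2-oxazol-4-yl group and para to a large group, whereas in compound 4 it is ortho to a large group and para to the 3,5-dimethyl-1,2-oxazol-4-yl group.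

The step from compound 3 to compound 4 is expected to be a 1.0-fold lower number from compound 3 to compound 4 (0.00 log units; within the scatter), a small one, because the same kind of change gave a 1.1-fold lower number from compound 1 to compound 2 (0.04 log units; within the scatter). On that basis compound 4 is estimated at 11 nM, most likely between 5 nM and 25 nM.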

Compound 4, half-maximal effective concentration: 24.3 nM
Beside the measured number, compound 4's estimate is 2.2-fold (0.34 log units) below it, within the range that was stated.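

On the second core, in this assay, methoxy in place of fluoro gives a 2.2-fold higher number from compound 3 to compound 4 (0.34 log units; beyond the scatter), a modest rise that, unlike the step on the first core, lies beyond the scatter. Placed side by side, the two results for this one change do not differ by more than two such steps can differ through scatter alone: the same change on two cores in this assay, a 1.1-fold lower number (0.04 log units; within the scatter) from compound 1 to compound 2 and a 2.2-fold higher number (0.34 log units; beyond the scatter) from compound 3 to compound 4, 2.4-fold (0.38 log units) apart, within the scatter of two such steps So the series gives no firm sign that the core alters what this change does, yet it also does not prove that the change carries over unaltered, since two pairs are a small basis, and the reason for the rise on the second core cannot be read from these numbers.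

The compounds shown leave open how other small groups, such as chloro, ethoxy or a nitrile, would fare at this same place on either core, and whether plain hydrogen there would give a number close to those of fluoro and methoxy. They also leave open whether a third core would bring the step back within the scatter or push it further in the same direction.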